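One More Group Swap on an Aromatic Nitrogen

The compounds below may be only part of what the source reports. "The series", "measured", "known", "first", "only" and "open" are said of these compounds alone.

- Compound 1 `Cc1ccc(C(C)C)c(OCc2cn(-c3ccc(O)cc3)nn2)c1`: 45400 nM
- Compound 2 `Cc1ccc(C(C)C)c(OCc2cn(-c3cccc(Cl)c3)nn2)c1`: 32100 nM
- Compound 3 `Cc1ccc(C(C)C)c(OCc2cn(-c3ccc(F)cc3)nn2)c1`: 22100 nM

All three numbers come from a functional assay on MCF7 cells (Homo sapiens) for inhibition, read by MTT assay, with a stated time of 72 h (a higher number here means a weaker inhibitor, a lower number a stronger inhibitor), and share one core, differing only in the group on an aromatic nitrogen. Compound 3 cannot be separated from compound 2, as a 1.5-fold lower number from compound 2 to compound 3 (0.16 log units; within the scatter) shows. It stands modestly clear of compound 1 only, with a 2.1-fold lower number from compound 1 to compound 3 (0.31 log units; beyond the scatter) as the measured gap.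

Compound 4 `Cc1ccc(C(C)C)c(OCc2cn(-c3ccccc3C)nn2)c1` has not yet been measured. Its change from compound 3 is this: 2-methylphenyl in place of 4-fluorophenyl on an aromatic nitrogen. The measured swaps at this same nitrogen bear on it. They are small, with a 1.4-fold lower number from compound 1 to compound 2 (0.15 log units; within the scatter) and a 1.5-fold lower number from compound 2 to compound 3 (0.16 log units; within the scatter) alongside the modest step already given. Within the data shown here, no measured compound carries 2-methylphenyl, so the data give no direction. In this assay the expected change is therefore none beyond the scatter, and the estimated step is a 1.2-fold higher number from compound 3 to compound 4 (0.09 log units; within the scatter) overall. For compound 4 the estimated value is 27000 nM, with an expected range from 12000 nM to 60000 nM.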

Compound 4, half-maximal inhibitory concentration: 6170 nM
Beside the measured number, compound 4's estimate is 4.4-fold (0.64 log units) above it; the measured number lies below the stated range.
By their numbers in this assay, from the lowest: compound 4; then compounds 3, 2 and 1 (each within the scatter of the next, the first and the last beyond it).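

With 2-methylphenyl on the aromatic nitrogen, this assay shows a 3.6-fold lower number from compound 3 to compound 4 (0.55 log units; beyond the scatter), a 5.2-fold lower number from compound 2 to compound 4 (0.72 log units; beyond the scatter) and a 7.4-fold lower number from compound 1 to compound 4 (0.87 log units; beyond the scatter). Among these compounds, this makes compound 4 the strongest inhibitor of the four, and it shows that a swap at this nitrogen can move the number further than the step among the earlier compounds, a 2.1-fold lower number from compound 1 to compound 3 (0.31 log units; beyond the scatter). No measurement shown here explains why this group gives the largest step.

Compared with compound 3, compound 4 differs in both the group on the phenyl ring and where that group sits, so the methyl and its place cannot be told apart. Plain phenyl, 4-methylphenyl and 2-fluorophenyl are not among the compounds shown, and they would be the direct comparisons for separating those two changes.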